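Ester capping of the acid tail in the amide series

The source may hold more compounds than are shown below. What is called first, only, known or untested is meant among the compounds shown, and "the series" means these compounds.

Compound 1 `CC(C)N(Cc1cccc(OCCCCCC(=O)O)c1)C(=O)c1ccc(-c2cccc3ccccc23)cc1` is known in an ADME assay on HEK293 cells (Homo sapiens) for cytotoxicity, read by CellTiter-Glo and resazurin assay, with a stated time of 72 h (a higher number here means that more compound is needed for the effect, a lower number that less compound is needed), only as a limit: in this assay compound 1 gives > 26000 nM. Compound 2 `CC(C)N(Cc1cccc(OCCCCCC(=O)O)c1)C(=O)c1ccc(-c2cccc(Cl)c2)cc1` is also known only as a limit, and in this assay compound 2 gives > 21900 nM. The step that the two limits leave unreadable from compound 1 to compound 2 is therefore unreadable. Compound 3 `CCOC(=O)CCCCCOc1cccc(CN(C(=O)c2ccc(-c3cccc4ccccc34)cc2)C(C)C)c1` differs from compound 1 by ethyl in place of hydrogen on an oxygen next to a carbonyl group. For the measured compounds named here, no measured step bears on this change, the only available comparison being unreadable. Compound 3 is expected to remain at a limit, and the step that the limit leaves unreadable from compound 1 to compound 3 is estimated to be small. The estimate for compound 3 in this assay is 30000 nM, range 8000 nM to 100000 nM.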

Compound 3, half-maximal effective concentration: > 26000 nM
Compound 3 gave a limit, no number; the forecaster's own chance of this, stated with the estimate: 80%; the middle value is on the limit's open side.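

Compound 1 and compound 3 are both known only as limits in this assay, so the step between them cannot be read. Whether ethyl in place of hydrogen shifts the half-maximal effective concentration stays open: the compounds shown give no exact value.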